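A Larger Ester Group on the Shared Core

The source may hold more compounds than are shown below. What is called first, only, known or untested is meant among the compounds shown, and "the series" means these compounds.

Of the compounds shown here, three with one shared core have been tested in an assay on membranes from CHO cells for displacement of a labelled ligand from adenosine receptor A1 (Homo sapiens), read by scintillation counting, with a stated time of 60 min, tested at 1 uM; a lower number here means less inhibition, a higher number more inhibition at the concentration tested (going by the name of the read-out). Compound 1 `CC1=C(C(=O)C2CC2)C(c2ccoc2)NC(=O)N1` gives 1%, and compound 2 `CC1=C(C(=O)NC(C)C)C(c2ccoc2)NC(=O)N1` gives 1%; the step of no change at the digits printed from compound 1 to compound 2 (within the scatter) leaves the two alike. Compound 3 `CCC(C)OC(=O)C1=C(C)NC(=O)NC1c1ccoc1` gives 13%, the highest of the three numbers, with the steps of a number 12 percentage points higher from compound 1 to compound 3 (beyond the scatter) and a number 12 percentage points higher from compound 2 to compound 3 (beyond the scatter) both rising beyond the scatter. Compound 4 `CC1=C(C(=O)OC2CCCCC2)C(c2ccoc2)NC(=O)N1` has not yet been measured; it differs from compound 3 by cyclohexyl in place of sec-butyl on an oxygen next to a carbonyl group. For the measured compounds named here, none of the measured steps touches this part of the molecule: all three change what stands on the carbonyl carbon, whereas compound 3 and compound 4 both carry an ester oxygen there. Going by the values given here, the two rising steps show only that the ester form of the shared core reaches the highest number so far. Among the compounds with values here, with no direct precedent, the change is expected to leave the number near where compound 3 stands, so a number 2 percentage points higher from compound 3 to compound 4 (within the scatter) is estimated to fall within the scatter. Compound 4 is therefore expected to give 15% in this assay, between 2% and 35%.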

Compound 4, a percentage reported as inhibition, at one concentration (the size of the read-out at that concentration, not a potency): 15%
Compound 4: the middle estimate sits on the measured number at the digits printed; measured number inside the range.
By their numbers in this assay, from the lowest: compounds 1 and 2 (each within the scatter of the next); then compounds 3 and 4 (each within the scatter of the next).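

On the oxygen next to a carbonyl group, cyclohexyl in place of sec-butyl brings a six-membered ring and 6 heavy atoms where an open chain of 4 stood, and the step reads a number 2 percentage points higher from compound 3 to compound 4 (within the scatter) in this assay; this position thus takes the ring without a change that can be told from the scatter. Against isopropylamino on the carbonyl carbon the step is a number 14 percentage points higher from compound 2 to compound 4 (beyond the scatter), and against cyclopropyl it is a number 14 percentage points higher from compound 1 to compound 4 (beyond the scatter), so the rise seen with sec-butoxy appears again with a second ester group. Nothing at hand bears on why these numbers fall as they do.

Going by these compounds, whether a phenyl group or a longer chain such as n-hexyl on the ester oxygen would move the number remains open. So does the effect of an amine or a carboxylic acid carried on the cyclohexyl ring.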